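Pyridin-2-yl on the cyclopropane: the step from compound 3

A few compounds are considered here, and "the series" means these few. Any claim that something is new, unique, unknown or untested is made for them only; others in the source may bear on it.

Compound 3 `CC[C@H](C)[C@H](N)CN(C(=O)[C@@H]1C[C@H]1c1cccc(C#N)c1)c1ccc(-c2ccccc2)cc1` gives 1600 nM in a functional assay for agonist activity at G protein-coupled receptor 88 (Homo sapiens), read by HTRF and cAMP accumulation; on this read-out higher numbers stand for an effect only at larger amounts of compound and lower numbers for an effect already at smaller amounts. That is the highest of the two numbers shown: compound 2 `CC[C@H](C)[C@H](N)CN(C(=O)[C@@H]1C[C@H]1c1ccccc1F)c1ccc(-c2ccccc2)cc1` gives 650 nM, and the step of a 2.5-fold higher number from compound 2 to compound 3 (0.39 log units; beyond the scatter) was modest. Compound 1 `CC[C@H](C)[C@H](N)CN(C(=O)[C@@H]1C[C@H]1c1ccc(OC)cc1)c1ccc(-c2ccccc2)cc1` reached only a limit, > 25000 nM, which is the limit of > 25000 nM in this assay, at which 1 of the 3 values shown sits. Compound 4 `CC[C@H](C)[C@H](N)CN(C(=O)[C@@H]1C[C@H]1c1ccccn1)c1ccc(-c2ccccc2)cc1` differs from compound 3 in one place: pyridin-2-yl in place of 3-cyanophenyl on a saturated ring carbon. Going by the values given here, all three measured steps are swaps of the aryl group on that same carbon, and two of them, an at least 38-fold lower number from compound 1 to compound 2 (1.58 log units; beyond the scatter) and an at least 15-fold lower number from compound 1 to compound 3 (1.19 log units; beyond the scatter), were large, while the third was modest; so such swaps can move the number considerably, yet no measured compound carries anything resembling pyridin-2-yl. The expectation for compound 4 is therefore a modest step, a 1.6-fold higher number from compound 3 to compound 4 (0.19 log units; within the scatter), with an estimated 2500 nM and a range from 700 nM to 9000 nM.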

Compound 4, half-maximal effective concentration: 130 nM
Beside the measured number, compound 4's estimate is 19-fold (1.28 log units) above it; measured number outside the range, below it.
By their numbers in this assay, from the lowest: compound 4; then compound 2; then compound 3. At a limit, above all of these: compound 1.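

With pyridin-2-yl on this saturated ring carbon, compound 4 gives the lowest number of the four in this assay, showing that an aromatic ring with a hetero atom can do better here than either carbon-only ring with a measured number: a 12-fold lower number from compound 3 to compound 4 (1.09 log units; beyond the scatter) and a 5.0-fold lower number from compound 2 to compound 4 (0.70 log units; beyond the scatter). The widest gap is an at least 190-fold lower number from compound 1 to compound 4 (2.28 log units; beyond the scatter). Compound 1 stands at a limit: the limit of > 25000 nM in this assay, at which 1 of the 4 values shown sits.

The compounds shown leave open whether unsubstituted phenyl, pyridin-3-yl or pyridin-4-yl would give a number like that of compound 4. Whether the ring nitrogen itself matters therefore stays undecided.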